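The source may hold more compounds than are shown below. What is called first, only, known or untested is meant among the compounds shown, and "the series" means these compounds.

Compounds measured in a functional assay on CHO cells for agonist activity at Free fatty acid receptor 1 (Homo sapiens); a lower number here means that less compound is needed, a higher number that more compound is needed for the effect:

compound 1, `CC(Cc1ccc(NCc2cccc(Oc3ccccc3)c2)cc1)C(=O)O`: 100 nM
compound 2, `CC(C)NC(=O)CCc1ccc(NCc2cccc(Oc3ccccc3)c2)cc1`: 39.8 nM

Among the measured compounds shown here, compound 2 gives the lowest of the two numbers; the one step known, a 2.5-fold lower number from compound 1 to compound 2 (0.40 log units; beyond the scatter), separates it from compound 1. Compound 3, `O=C(CCc1ccc(NCc2cccc(Oc3ccccc3)c2)cc1)N1CCCC1`, differs from compound 2 by pyrrolidin-1-yl in place of isopropylamino on a carbonyl carbon. For the measured compounds named here, no measured step changes the group on the carbonyl carbon, so that earlier step gives no direct guide; with the chain and the shared core kept, compound 3 is expected to stay close to compound 2, with the step of a 1.3-fold higher number from compound 2 to compound 3 (0.10 log units; within the scatter) expected to lie within the scatter. The estimate for compound 3 is 50 nM, between 15 nM and 160 nM.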

Compound 3, half-maximal effective concentration: 115 nM
The estimate for compound 3 lay 2.3-fold (0.36 log units) below the measured number; the measured number falls inside the stated range.
By their numbers in this assay, from the lowest: compound 2; then compounds 1 and 3 (each within the scatter of the next).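

In this assay, the group on the carbonyl carbon matters: pyrrolidin-1-yl in place of isopropylamino removes the amide hydrogen and gives a 2.9-fold higher number from compound 2 to compound 3 (0.46 log units; beyond the scatter), so the advantage of compound 2 over compound 1 does not carry over to this ring. The comparison with the carboxylic acid shows a 1.2-fold higher number from compound 1 to compound 3 (0.06 log units; within the scatter), which leaves these two compounds indistinguishable. Nothing available explains why this change has that effect. From the compounds shown here alone, it remains open whether the missing amide hydrogen or the ring accounts for the step, which dimethylamino on the same carbonyl carbon could help separate.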